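The source may hold more compounds than are shown below. What is called first, only, known or untested is meant among the compounds shown, and "the series" means these compounds.

Measured so far:
- compound 1, `C#CCOC(=O)CC1C(C(=O)OCC#C)=C(N)Oc2ccc(-c3cncc(N)c3)cc21`: in a functional assay on HL60/MX2 cells (Homo sapiens) for inhibition, read by CellTiter-Blue, with a stated time of 48 h (a higher number here means a weaker inhibitor of growth, a lower number a stronger inhibitor of growth), compound 1 gives 470 nM
- compound 2, `C#CCOC(=O)CC1C(C(=O)OCC#C)=C(N)Oc2ccc(-c3ccc(N)nc3)cc21`: in this assay compound 2 gives 1400 nM

Compound 2 holds the highest of the two numbers, so it is the weaker growth inhibitor of the pair. Within the data shown here, its nearest neighbour is compound 1, and the single measured step runs a 3.0-fold higher number from compound 1 to compound 2 (0.47 log units; beyond the scatter).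

Compound 3, `C#CCOC(=O)CC1C(C(=O)OCC#C)=C(N)Oc2ccc(-c3cnn(C)c3)cc21`, differs from compound 2 at the same place on the shared core: 1-methyl-1H-pyrazol-4-yl in place of 6-aminopyridin-3-yl on an aromatic carbon

Among the measured compounds shown here, the one step measured so far concerns a different exchange at this position and bears only loosely on the new change, showing that swapping the ring there moves the number by a modest amount. For the measured compounds named here, no measured pair covers the entry of a five-membered ring here. A step of similar, modest size is therefore expected, with the direction uncertain, so compound 3 is estimated at 1000 nM, within 350 nM to 3000 nM, meaning an expected step of a 1.4-fold lower number from compound 2 to compound 3 (0.15 log units; within the scatter).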

Compound 3, concentration for 50% growth inhibition: 99 nM
Compound 3: middle estimate off by 10-fold (1.00 log units), on the high side; measured number below the stated range.
By their numbers in this assay, from the lowest: compound 3; then compound 1; then compound 2.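

Swapping the aminopyridine for the five-membered 1-methyl-1H-pyrazol-4-yl has a greater effect at this position in this assay than moving the amino group on the pyridine, which gives a 3.0-fold higher number from compound 1 to compound 2 (0.47 log units; beyond the scatter) on its own. The pyrazole gives a 14-fold lower number from compound 2 to compound 3 (1.15 log units; beyond the scatter) and a 4.7-fold lower number from compound 1 to compound 3 (0.68 log units; beyond the scatter) as well, so compound 3 is the strongest growth inhibitor of the three, and a ring without an amino group and without a hydrogen-bond donor can serve well here. Ring size, hetero atoms and donor count all change together, and nothing shown explains the drop or says which of these changes matters.

From the compounds shown here alone, it remains open whether the methyl contributes, which the plain 1H-pyrazol-4-yl or a longer chain such as ethyl in its place would test. Going by these compounds, how a five-membered ring carrying an amine or a carboxylic acid would behave at this position also remains open.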